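The source may hold more compounds than are shown below. What is called first, only, known or untested is meant among the compounds shown, and "the series" means these compounds.

Measured so far in a functional assay on Hep 3B2 cells (Homo sapiens) for cytotoxicity, read by MTT assay, with a stated time of 72 h; on this read-out higher numbers stand for weaker inhibition and lower numbers for stronger inhibition:
compound 1 `CCCC/C(=C\c1cc(OC)c(OC)c(OC)c1)C(=O)N1CCC=C(Cl)C1=O` — 14800 nM
compound 2 `COc1cc(/C=C(\C)C(=O)N2CCC=C(Br)C2=O)cc(OC)c1OC` — 3100 nM
compound 3 `CCCC/C(=C\c1cc(OC)c(OC)c(OC)c1)C(=O)N1CCC=C(Br)C1=O` — 14900 nM

Compound 1 sits second highest of the three numbers in this assay. Its nearest neighbour is compound 3, where a 1.0-fold higher number from compound 1 to compound 3 (0.00 log units; within the scatter); the two are not separable. Going by the values given here, compound 2 stands apart below, the only step beyond the scatter in the set.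

Compound 4 `CCC/C(=C\c1cc(OC)c(OC)c(OC)c1)C(=O)N1CCC=C(Cl)C1=O` is the next member. Against compound 1 the change is hydrogen in place of methyl on a saturated chain carbon, three bonds along the chain from a double-bonded chain carbon; read one bond further out it is butyl to propyl.

Among the compounds with values here, one measured step bears on this direction. From compound 2 to compound 3 the chain on the double-bonded chain carbon grows, and a 4.8-fold higher number from compound 2 to compound 3 (0.68 log units; beyond the scatter); a longer chain there goes with a higher number. Compound 4 moves the other way, but by a single carbon rather than the full propyl, so only a fraction of that step is expected, towards a lower number, and it may not clear the scatter. The remaining pair, compound 1 to compound 3, shows a halogen swap with no movement and says nothing about the chain.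

Compound 4 is therefore estimated at 10000 nM in this assay, within 4000 nM to 25000 nM, meaning an expected step of a 1.5-fold lower number from compound 1 to compound 4 (0.17 log units; within the scatter).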

Compound 4, half-maximal inhibitory concentration: 22400 nM
For compound 4 the middle estimate is 2.2-fold (0.35 log units) below the measured one; low and high end bracket the measured number.
By their numbers in this assay, from the lowest: compound 2; then compounds 1, 3 and 4 (each within the scatter of the next).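

In this assay the change from butyl to propyl, hydrogen in place of methyl on a saturated chain carbon, three bonds along the chain from a double-bonded chain carbon, gives a 1.5-fold higher number from compound 1 to compound 4 (0.18 log units; within the scatter) and leaves the two compounds inseparable, so removing this single outer carbon has no readable effect. The larger chain change, a 4.8-fold higher number from compound 2 to compound 3 (0.68 log units; beyond the scatter) in the bromo compounds, is therefore not shown to shrink in step with a single carbon, and a steady dependence on chain length is not supported, though compound 2 and compound 4 differ in both the chain and the halogen and cannot be compared directly. The compounds shown offer no measured evidence that would explain this flat stretch of the chain.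

Still open, as far as these compounds go, is where the movement towards the number of compound 2 begins: an ethyl chain, and a methyl chain paired with the chloro group of compound 1, would place it on a single-change footing. A longer chain such as hexyl would show whether the flat stretch from propyl to butyl continues outwards.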